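This account rests on a few compounds, and the source may have more. Where it says the series, first, only, none or still open, it means among the compounds named here.

Three compounds of this series carry a value in a functional assay on SF-268 cells (Homo sapiens) for inhibition, read by sulforhodamine B assay, with a stated time of 48 h; a higher number here means a weaker inhibitor of growth, a lower number a stronger inhibitor of growth. Compound 1 `COc1ccc(-c2[nH]c3ccccc3c2/C=C(\C#N)S(=O)(=O)c2ccccc2)cc1` gives 1100 nM. Compound 2 `COc1ccc2[nH]c(-c3ccccc3)c(C=C(C#N)C#N)c2c1` gives 8300 nM. Compound 3 `CCOC(=O)C(=Cc1c(-c2ccccc2)[nH]c2ccccc12)C(=O)OCC` gives 6800 nM. Compound 1 stands lowest of the three; its nearest neighbour is compound 3, a gap beyond the scatter, and the furthest is compound 2, also beyond the scatter. Both compound 2 and compound 3 differ from compound 1 in more than one place, so neither gap can be tied to a single structural change.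

Compound 4 `COc1ccc(-c2[nH]c3ccc(OC)cc3c2/C=C(\C#N)S(=O)(=O)c2ccccc2)cc1` has not yet been measured in this assay. Relative to compound 1 the change is methoxy in place of hydrogen on an aromatic carbon. Among the compounds with values here, no measured pair isolates this change. Within the data shown here, compound 2 is the only other compound with a methoxy on the fused system of two rings, yet it differs from compound 1 elsewhere too, and its value alone cannot be read as the effect of that methoxy. The step from compound 1 to compound 4 is expected to be small, in either direction, and not beyond the scatter: no change at the digits printed from compound 1 to compound 4 (within the scatter). Compound 4 is accordingly estimated at 1100 nM, with an expected range of 400 nM to 3000 nM.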

Compound 4, concentration for 50% growth inhibition: 1600 nM
Estimate against measurement, compound 4: 1.5-fold (0.16 log units) below; the range from low to high includes it.
By their numbers in this assay, from the lowest: compounds 1 and 4 (each within the scatter of the next); then compounds 3 and 2 (each within the scatter of the next).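

In this assay, the only comparison shown that differs in one place is methoxy in place of hydrogen on an aromatic carbon of the fused system of two rings, meta to a fused ring and para to a fused ring: a 1.5-fold higher number from compound 1 to compound 4 (0.16 log units; within the scatter), a step that stays within the scatter. The earlier compounds shown here could not isolate this change, whereas this pair shows that, on the core of compound 1, a methoxy at this position leaves growth inhibition indistinguishable from that with hydrogen. No measurement on hand bears on why the step is this small, so no cause can be given for it.

The compounds shown do not tell whether this position accepts other groups equally, such as a longer chain like butoxy, an amine or a carboxylic acid, or whether a step beyond the scatter appears with any of them. They also leave open whether methoxy at this position gives a comparable step when the sulfonyl-bearing side chain of compound 1 is replaced by a dinitrile or a diethyl ester.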